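Swapping the side chain of compound 3

A few compounds are considered here, and "the series" means these few. Any claim that something is new, unique, unknown or untested is made for them only; others in the source may bear on it.

Compound 1 `COc1ccc2c(c1)NC(=O)CN2c1nc(COC(C)=O)nc2ccccc12`: 5.05 nM
Compound 2 `COc1ccc2c(c1)NC(=O)CN2c1nc(Nc2cccc(C#N)c2)nc2ccccc12`: 61.5 nM
Compound 3 `COc1ccc2c(c1)NC(=O)CN2c1nc(NCCCO)nc2ccccc12`: 4.92 nM

These numbers come from a functional assay on KB cells (Homo sapiens) for inhibition, read by sulforhodamine B assay, with a stated time of 48 h; on this read-out higher numbers stand for weaker inhibition of growth and lower numbers for stronger inhibition of growth. Compound 3 stands at 4.92 nM, level with compound 1 within the scatter, and clearly apart from the third member of the set: a 13-fold lower number from compound 2 to compound 3 (1.10 log units; beyond the scatter).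

The next molecule, compound 4 `COc1ccc2c(c1)NC(=O)CN2c1nc(COCCCC(=O)NO)nc2ccccc12`, keeps the shared core and changes one group: (3-(hydroxycarbamoyl)propoxy)methyl in place of (3-hydroxypropyl)amino on an aromatic carbon. In words, (3-(hydroxycarbamoyl)propoxy)methyl replaces (3-hydroxypropyl)amino on the aromatic carbon between two ring nitrogen atoms.

Two measured steps at this same carbon bear on the change. Exchanging one ring-free group for another made no real difference: a 1.0-fold lower number from compound 1 to compound 3 (0.01 log units; within the scatter). Bringing in the ring of (3-cyanophenyl)amino gave a large jump: a 12-fold higher number from compound 1 to compound 2 (1.09 log units; beyond the scatter). Within the data shown here, the entering group has no ring, so the first step is the closer guide, although no measured compound carries a hydroxycarbamoyl group. A small rise in the number is therefore expected, with a larger one not ruled out.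

In this assay the expected change is a 1.8-fold higher number from compound 3 to compound 4 (0.26 log units; within the scatter). For compound 4 the estimated value is 9 nM, with an expected range from 3 nM to 35 nM.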

Compound 4, concentration for 50% growth inhibition: 307 nM
For compound 4 the middle estimate is 34-fold (1.53 log units) below the measured one; the whole stated range lies below it.
By their numbers in this assay, from the lowest: compounds 3 and 1 (each within the scatter of the next); then compound 2; then compound 4.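

At this carbon, a side chain without a ring does not guarantee a level result in this assay: compound 4 carries no ring, yet the exchange gives a large rise (a 62-fold higher number from compound 3 to compound 4 (1.80 log units; beyond the scatter)), whereas the earlier exchange of one ring-free group for another changed nothing within the scatter. Compound 1 and compound 4 both keep a methylene and an oxygen on this carbon, so the large step here (a 61-fold higher number from compound 1 to compound 4 (1.78 log units; beyond the scatter)) comes with a change only further out, where 3-(hydroxycarbamoyl)propyl takes the place of acetyl. The ring of compound 2 is also not the only feature that goes with a higher number, since the ring-free compound 4 stands clearly above it (a 5.0-fold higher number from compound 2 to compound 4 (0.70 log units; beyond the scatter)).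

Nothing available here gives a measured reason for these rises. The compounds shown leave open whether the hydroxycarbamoyl end or the length of the chain matters more, and a carboxylic acid or a primary amide at the end of the same chain, or a shorter chain still ending in hydroxycarbamoyl, would help separate the two.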